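The source may hold more compounds than are shown below. What is called first, only, known or untested is meant among the compounds shown, and "the series" means these compounds.

Measured so far in a physicochemical assay for lipophilicity, read by spectrophotometry, using the shake flask method, measured as octanol-water partition; on this read-out higher numbers stand for higher lipophilicity and lower numbers for lower lipophilicity:
compound 1 `FC(F)OCCc1ccccc1` gives 3.16
compound 2 `COCCc1ccccc1` gives 2.23
compound 3 `C[S+]([O-])CCc1ccccc1` gives 0.63

Compound 3 stands lowest of the three; its nearest neighbour is compound 2 and the furthest is compound 1, and both of those gaps lie beyond the usual scatter. Compound 4 `FC(F)CCc1ccccc1` differs from compound 3 in one place: a group of 3 heavy atoms (1 carbon, 2 fluorine; no ring) in place of a group of 3 heavy atoms (1 carbon, 1 oxygen, 1 sulfur; no ring), on a saturated chain carbon, two bonds along the chain from an aromatic carbon. For the measured compounds named here, two measured steps bear on this change, a number 2.53 log units lower from compound 1 to compound 3 (beyond the scatter) and a number 1.60 log units lower from compound 2 to compound 3 (beyond the scatter), and each shows that bringing in the group that compound 3 carries pushed the number down by a large amount. Taking that group out again, and putting in the difluoromethyl that compound 1 also carries, is expected to reverse this, so a large upward step in this assay is expected. The estimated step is a number 2.67 log units higher from compound 3 to compound 4 (beyond the scatter), and compound 4 is estimated at 3.3, in a range from 2.8 to 3.8.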

Compound 4, partition coefficient: 3.02
Estimate against measurement, compound 4: 0.28 log units above, within the range that was stated.
By their numbers in this assay, from the lowest: compound 3; then compound 2; then compounds 4 and 1 (each within the scatter of the next).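

In this assay, difluoromethyl on the saturated chain carbon gives a number 2.39 log units higher from compound 3 to compound 4 (beyond the scatter) when it replaces the sulfur-bearing group, and a number 0.79 log units higher from compound 2 to compound 4 (beyond the scatter) when it replaces methoxy. Set against difluoromethoxy, the same group gives a number 0.14 log units lower from compound 1 to compound 4 (within the scatter), so compound 1 and compound 4 cannot be told apart here.

Nothing measured here gives a reason for these steps. Where a trifluoromethyl or an amine at this place would fall among these numbers remains open.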